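Methoxyphenyl in place of thiophenyl on the shared core

The source may hold more compounds than are shown below. What is called first, only, known or untested is meant among the compounds shown, and "the series" means these compounds.

Of the compounds shown here, two have been measured in an assay on CHO cells for displacement of a labelled ligand from adenosine receptor A1 (Homo sapiens), read by scintillation counting, with a stated time of 120 min, tested at 1 uM; a higher number here means more inhibition at the concentration tested (going by the name of the read-out), a lower number less inhibition. Compound 1 `COc1ccc(-c2nc(N)c3nn(-c4ccccc4)cc3n2)cc1` gives 33% in this assay. Compound 2 `COc1ccc(-n2cc3nc(-c4cccs4)nc(N)c3n2)cc1` gives 28% in this assay. Among the compounds with values here, the two numbers sit apart by less than the usual scatter, so compound 2 cannot be told from compound 1 on these data; both show modest inhibition at the concentration tested, and no step beyond the scatter has been observed so far.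

Compound 3 `COc1ccc(-c2nc(N)c3nn(-c4ccc(OC)cc4)cc3n2)cc1` is the next compound, not yet measured. It differs from compound 2 at one place: 4-methoxyphenyl in place of thiophen-2-yl on an aromatic carbon. The group that enters is the same group that compound 1 carries on an aromatic carbon of a six-membered aromatic ring with 2 nitrogen, between two ring nitrogen atoms, and compound 1 gives 33% there.

Within the data shown here, with only two measured values, both close to each other, the expected step from compound 2 to compound 3 in this assay is a number 4 percentage points higher from compound 2 to compound 3 (within the scatter), i.e. none beyond the scatter. Compound 3 is therefore estimated at 32% in this assay, with a range from 15% to 50%.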

Compound 3, a percentage reported as inhibition, at one concentration (the size of the read-out at that concentration, not a potency): 1%
Compound 3: middle estimate off by 31 percentage points, on the high side, and the stated range ends above it.
By their numbers in this assay, from the lowest: compound 3; then compounds 2 and 1 (each within the scatter of the next).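

In this assay, within the data shown here, the group on the aromatic carbon between two ring nitrogen atoms proves not to be interchangeable: 4-methoxyphenyl in place of thiophen-2-yl gives a number 27 percentage points lower from compound 2 to compound 3 (beyond the scatter), the first step beyond the scatter. Among these compounds, the cleaner reading comes from the other pair, where the only change is methoxy in place of hydrogen on an aromatic carbon of the phenyl at this place: that single group gives a number 32 percentage points lower from compound 1 to compound 3 (beyond the scatter), and compound 3 stands at 1%, so the number in this assay is lower with 4-methoxyphenyl than with phenyl at this place at the concentration tested. Nothing at hand gives a reason for this loss.

Still open, going by these compounds, is whether the loss belongs to methoxy itself or to any group on that phenyl, which a fluorine, a hydroxyl or an amine in the same place would help to settle. Also open, on these data alone, is whether a longer chain such as ethoxy would behave like methoxy, and all of these readings rest on a single concentration, so they say nothing of potency.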